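A few compounds are considered here, and "the series" means these few. Any claim that something is new, unique, unknown or untested is made for them only; others in the source may bear on it.

Measured in a functional assay on MCF7 cells (Homo sapiens) for cytotoxicity, read by MTT assay, with a stated time of 72 h; on this read-out higher numbers stand for weaker inhibition and lower numbers for stronger inhibition:
- compound 1 (`NCCCNc1c(C(=O)NCc2ccc(F)cc2)nc(Br)c2cccnc12`) gives 6000 nM
- compound 2 (`N[C@H]1CC[C@H](Nc2c(C(=O)NCc3ccc(Oc4ccccc4)cc3)nc(Br)c3cccnc23)CC1`) gives 7900 nM
- compound 3 (`O=C(NCc1ccc(F)cc1)c1nc(Br)c2cccnc2c1NCc1ccc(F)cc1`) gives "not determined" (no result reported)

For the measured compounds named here, compound 3 therefore has no number, and no step can be measured from it. The change 4-aminocyclohexyl in place of 4-fluorobenzyl on a nitrogen on an aromatic ring puts 4-aminocyclohexyl in place of 4-fluorobenzyl on a nitrogen on an aromatic ring, giving compound 4 (`N[C@H]1CC[C@H](Nc2c(C(=O)NCc3ccc(F)cc3)nc(Br)c3cccnc23)CC1`), which is not yet measured. Compound 4 carries the 4-aminocyclohexyl of compound 2 and the 4-fluorobenzyl of compound 1. The values of these two neighbours lie within the scatter of each other, so in this assay no step beyond the scatter from either is expected, in either direction. Compound 4 is estimated at 6500 nM with an expected range from 2500 nM to 15000 nM.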

Compound 4, half-maximal inhibitory concentration: 2000 nM
The estimate for compound 4 lay 3.3-fold (0.51 log units) above the measured number, and the stated range ends above it.
By their numbers in this assay, from the lowest: compound 4; then compounds 1 and 2 (each within the scatter of the next).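

In this assay, 4-aminocyclohexyl in place of 3-aminopropyl on a nitrogen on an aromatic ring gives a 3.0-fold lower number from compound 1 to compound 4 (0.48 log units; beyond the scatter), so the group at this position affects the number when the rest of the molecule is unchanged. Fluoro in place of phenoxy on an aromatic carbon gives a 4.0-fold lower number from compound 2 to compound 4 (0.60 log units; beyond the scatter), so a change at this second place also moves the number beyond the scatter. Compound 3 has no number, so its step to compound 4 cannot be read, and no measurement here offers an explanation for either step. Going by these compounds, it remains open whether a hydroxyl in place of the amine on the cyclohexyl ring, or chloro in place of fluoro, would keep the number of compound 4.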